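Methoxy on the Benzoate of a Phenolic Ester Core

The compounds below may be only part of what the source reports. "The series", "measured", "known", "first", "only" and "open" are said of these compounds alone.

Measured compounds: compound 1 `Cc1cc2c(C(C)C)ccc(C)c2cc1OC(=O)c1cccc(C(F)(F)F)c1`, "not active" (no number reported); compound 2 `CC1=CC[C@H](C(C)C)c2cc(C)c(OC(=O)c3ccccc3)cc21`, "not active" (no number reported); compound 3 `CC1=CC[C@H](C(C)C)c2cc(C)c(OC(=O)c3cccc(C(F)(F)F)c3)cc21`, 45.5%.

In a functional assay on K562 cells (Homo sapiens) for antiproliferative activity, read by sulforhodamine B assay, with a stated time of 48 h, tested at 50 uM (a higher number here means more inhibition at the concentration tested (going by the name of the read-out), a lower number less inhibition), compound 2 is reported as inactive, without a number. Compound 1 is also reported inactive in this assay, without a number, whereas compound 3 gives 45.5%. Going by the values given here, compound 2 thus stands among the compounds for which no figure was recorded, and no step to compound 3 is available.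

Compound 4 `COc1ccc(C(=O)Oc2cc3c(cc2C)[C@@H](C(C)C)CC=C3C)cc1` differs from compound 2 by methoxy in place of hydrogen on an aromatic carbon. With compound 2 giving no number in this assay, the step to compound 4 cannot be anchored; a small step, within the scatter, is expected, and compound 2 may again end without a number. For compound 4 the estimated inhibition is 15%, between 0% and 40%.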

Compound 4, a percentage reported as inhibition, at one concentration (the size of the read-out at that concentration, not a potency): 46.5%
Beside the measured number, compound 4's estimate is 31.5 percentage points below it; the whole stated range lies below it.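

Going by these compounds alone, compound 2 carries no number, so no step to compound 4 can be read. The compounds shown leave open how much the methoxy contributes to the reading of compound 4, and no measured evidence bears on this.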